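Swapping the triazole substituent on a weak antiproliferative series

The source may hold more compounds than are shown below. What is called first, only, known or untested is meant among the compounds shown, and "the series" means these compounds.

Compound 1 `CN(CCNCc1cn(-c2ccccc2Cl)nn1)CCNc1ccnc2cc(Cl)ccc12` and compound 2 `CN(CCNCc1cn(-c2ccnc3cc(Cl)ccc23)nn1)CCNc1ccnc2cc(Cl)ccc12` share one core and differ only in the group carried on the aromatic nitrogen of the triazole. In a functional assay on HCC827 cells (Homo sapiens) for antiproliferative activity, read by sulforhodamine B assay, with a stated time of 72 h (on this read-out higher numbers stand for weaker inhibition and lower numbers for stronger inhibition), compound 1 gives 12000 nM, and compound 2 gives 18000 nM. Among the compounds with values here, the step of a 1.5-fold higher number from compound 1 to compound 2 (0.18 log units; within the scatter) is the only measured comparison available, and it shows that exchanging one aryl group for another at this position left the read-out essentially unchanged. Compound 2 thus carries the highest of the two numbers, though its nearest neighbour, compound 1, lies within the scatter.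

Compound 3 `CN(CCNCc1cn(CCC(=O)Nc2ccccn2)nn1)CCNc1ccnc2cc(Cl)ccc12` is the next member and changes the same position: 2-((pyridin-2-yl)carbamoyl)ethyl in place of 7-chloroquinolin-4-yl on an aromatic nitrogen. Within the data shown here, the single step that bears on this position, from compound 1 to compound 2, was within the scatter, so compound 3 is expected to move by a 1.2-fold lower number from compound 2 to compound 3 (0.08 log units; within the scatter), which is no step beyond the scatter in either direction. Compound 3 is therefore estimated at 15000 nM in this assay, within a range from 5000 nM to 45000 nM.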

Compound 3, half-maximal inhibitory concentration: > 200000 nM
Compound 3: only a limit was reported; the forecaster's own chance of this, stated with the estimate: 15%; middle value at least 13-fold (1.12 log units) from the limit.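

The position is therefore not indifferent to what it carries, even though the exchange of one aryl group for another gave only a 1.5-fold higher number from compound 1 to compound 2 (0.18 log units; within the scatter). Replacing either aryl group with the 2-((pyridin-2-yl)carbamoyl)ethyl chain gives a change of a different order: an at least 11-fold higher number from compound 2 to compound 3 (1.04 log units; beyond the scatter), and an at least 16-fold higher number from compound 1 to compound 3 (1.22 log units; beyond the scatter). For compound 3, only a limit was reported in this assay, so these steps mark how far the read-out moved at the least, and this compound stands alone among those shown: the limit of > 200000 nM in this assay, at which 1 of the 3 values shown sits.

The change from compound 2 to compound 3 alters several features at once, removing the six-membered aromatic ring of carbon only and bringing in an amide carbonyl, an amide hydrogen and a flexible chain, so the compounds shown leave open which of these parts goes with the loss. A simple ethyl chain ending in an amine or a carboxylic acid, or a plain phenyl group on the same aromatic nitrogen, would help to separate the contribution of the chain from that of the pyridin-2-yl amide.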